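Carbonyl substituent change at the piperidine amide of compound 1

The compounds below may be only part of what the source reports. "The series", "measured", "known", "first", "only" and "open" are said of these compounds alone.

Measured compounds in an assay on isolated protein for displacement of a labelled ligand from secreted frizzled-related protein 1 (Homo sapiens), read by fluorescence polarization, with a stated time of 30 min; on this read-out lower numbers stand for stronger inhibition and higher numbers for weaker inhibition:
- compound 1 `O=C(c1ccc(Cl)cc1)N1CCC(NS(=O)(=O)c2cc(S(=O)(=O)c3ccccc3)ccc2C(F)(F)F)CC1` gives 300 nM
- compound 2 `O=C(O)c1cccc(S(=O)(=O)N2CCC(NS(=O)(=O)c3cc(S(=O)(=O)c4ccccc4)ccc3C(F)(F)F)CC2)c1` gives 20 nM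
- compound 3 `CC(C)(O)CCN1CCC(NS(=O)(=O)c2cc(S(=O)(=O)c3ccccc3)ccc2C(F)(F)F)CC1` gives 200 nM

Compound 1 stands at the highest number of the three. Its gap to compound 3 is a 1.5-fold lower number from compound 1 to compound 3 (0.18 log units; within the scatter), which is within the scatter, so the two cannot be ordered. Its gap to compound 2 is a 15-fold lower number from compound 1 to compound 2 (1.18 log units; beyond the scatter), a large step to a lower number.

Compound 4 `CC(C)(C)OC(=O)N1CC[C@@H](C(=O)N2CCC(NS(=O)(=O)c3cc(S(=O)(=O)c4ccccc4)ccc3C(F)(F)F)CC2)C1` is not yet measured. It differs from compound 1 thus: 1-(tert-butoxycarbonyl)pyrrolidin-3-yl in place of 4-chlorophenyl on a carbonyl carbon. The carbonyl on the ring nitrogen is kept; only the group on that carbonyl carbon is exchanged.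

Neither measured step bears directly on this. The steps of a 15-fold lower number from compound 1 to compound 2 (1.18 log units; beyond the scatter) and a 1.5-fold lower number from compound 1 to compound 3 (0.18 log units; within the scatter) each remove the whole (4-chlorophenyl)carbonyl from the ring nitrogen rather than exchanging the group on the carbonyl carbon. The large step appears only with (3-carboxyphenyl)sulfonyl; the 3-hydroxy-3-methylbutyl change stays within the scatter. With the amide retained in compound 4, a step within the scatter is expected, with some room toward a lower number.

Compound 4 is therefore estimated at 250 nM, with a range of 100 nM to 700 nM, which means an expected step of a 1.2-fold lower number from compound 1 to compound 4 (0.08 log units; within the scatter).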

Compound 4, half-maximal inhibitory concentration: 50 nM
The estimate for compound 4 lay 5.0-fold (0.70 log units) above the measured number; measured number below the stated range.
By their numbers in this assay, from the lowest: compound 2; then compound 4; then compounds 3 and 1 (each within the scatter of the next).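

In this assay, for the compounds shown here, the step of a 6.0-fold lower number from compound 1 to compound 4 (0.78 log units; beyond the scatter) comes with the carbonyl on the ring nitrogen kept, so the group on that carbonyl carbon matters on its own, which the earlier steps could not show, as they removed the whole (4-chlorophenyl)carbonyl. Until now a step beyond the scatter from compound 1 had appeared only with (3-carboxyphenyl)sulfonyl, whereas here one appears with an entering group of no net charge, so a carboxylic acid is not required for such a step in these compounds, and a six-membered aromatic ring of carbon only is not required on this carbonyl carbon. No measurement at hand accounts for the size of this step.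

On these data alone, it remains open which part of the 1-(tert-butoxycarbonyl)pyrrolidin-3-yl group goes with the lower number: the tert-butoxycarbonyl, the five-membered non-aromatic ring or the defined stereocentre. The free pyrrolidine amine, the opposite configuration at the stereocentre, or a carboxylic acid on the same ring would help to separate these parts.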